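From tert-butyl to trifluoromethyl on the shared core

The source may hold more compounds than are shown below. What is called first, only, known or untested is meant among the compounds shown, and "the series" means these compounds.

In a functional assay on MCF7 cells (Homo sapiens) for cytotoxicity, read by MTT assay, with a stated time of 48 h (on this read-out higher numbers stand for weaker inhibition and lower numbers for stronger inhibition), compound 1 (`CC(C)(C)c1ccc(-c2cnc3c(c2)C=CS(=O)(=O)O3)cc1`) gives > 500000 nM, which is a limit and not a number. Going by the values given here, compound 2 (`O=S1(=O)C=Cc2cc(-c3cc(Cl)cc(Cl)c3)cnc2O1`) gives 20000 nM, the only true number so far. Compound 3 (`O=S1(=O)C=Cc2cc(-c3ccc(C(F)(F)F)cc3)cnc2O1`) differs from compound 1 as follows: trifluoromethyl in place of tert-butyl on an aromatic carbon. That is trifluoromethyl in place of tert-butyl on an aromatic carbon. The expected result in this assay is a step toward stronger inhibition, beyond the scatter, estimated as an at least 8.3-fold lower number from compound 1 to compound 3 (0.92 log units; beyond the scatter). The value of compound 2 at 20000 nM anchors this expectation. For compound 3 the estimated value is 60000 nM, with an expected range of 15000 nM to 300000 nM.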

Compound 3, half-maximal inhibitory concentration: 75000 nM
Compound 3: the middle estimate sits 1.3-fold (0.10 log units) below what was measured; the range from low to high includes it.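

On this aromatic carbon of the six-membered ring, trifluoromethyl in place of tert-butyl gives an at least 6.6-fold lower number from compound 1 to compound 3 (0.82 log units; beyond the scatter) in this assay, the first sign that this position responds to the group it carries. Both groups have the same heavy-atom count and neither has a hydrogen-bond donor or acceptor, so those counts do not separate them. The value of compound 1 is a limit, not a number, so the step has no upper bound: the limit of > 500000 nM in this assay, at which 1 of the 3 values shown sits.

Still open, from the compounds shown here alone, is how an amine, a carboxylic acid or a longer chain would read at this position.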